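The source may hold more compounds than are shown below. What is called first, only, known or untested is meant among the compounds shown, and "the series" means these compounds.

Measured in a physicochemical assay for solubility; on this read-out higher numbers stand for higher solubility and lower numbers for lower solubility:
- compound 1 `CN(C)c1ccc(C(=O)N2CCC(NS(=O)(=O)c3cc(S(=O)(=O)c4ccccc4)ccc3C(F)(F)F)CC2)cn1`: 12500 nM
- compound 2 `O=C(O)c1cccc(S(=O)(=O)N2CCC(NS(=O)(=O)c3cc(S(=O)(=O)c4ccccc4)ccc3C(F)(F)F)CC2)c1`: 12500 nM
- compound 3 `CC(C)(C)OC(=O)N1CC[C@H](C(=O)N2CCC(NS(=O)(=O)c3cc(S(=O)(=O)c4ccccc4)ccc3C(F)(F)F)CC2)C1`: 25000 nM

Compound 3, at 25000 nM, lies within the usual scatter of the other two values, so these three compounds cannot be ranked. The next compound, compound 4 `O=C([C@@H]1CCNC1)N1CCC(NS(=O)(=O)c2cc(S(=O)(=O)c3ccccc3)ccc2C(F)(F)F)CC1`, differs from compound 3 in one place, on a carbonyl carbon: pyrrolidin-3-yl in place of 1-(tert-butoxycarbonyl)pyrrolidin-3-yl on a carbonyl carbon. The five-membered non-aromatic ring stays, and the tert-butoxycarbonyl part goes.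

Within the data shown here, no measured step makes this exact change, but two changed the same part of the molecule. The first, a 2.0-fold higher number from compound 1 to compound 3 (0.30 log units; within the scatter), swapped the group on that carbonyl carbon. The second, no change at the digits printed from compound 1 to compound 2 (within the scatter), replaced the whole group on the ring nitrogen. Both stayed within the scatter, although neither is a close match for this change. In this assay, therefore, no step beyond the scatter is expected, and this is a weakly supported expectation.

The estimated step is no change at the digits printed from compound 3 to compound 4 (within the scatter). The expected value for compound 4 is 25000 nM, with an estimated range from 12000 nM to 60000 nM.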

Compound 4, solubility: 12500 nM
The estimate for compound 4 lay 2.0-fold (0.30 log units) above the measured number; measured number inside the range.
By their numbers in this assay, from the lowest: compounds 1, 2, 4 and 3 (each within the scatter of the next).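

In this assay the loss of the tert-butoxycarbonyl part gives a 2.0-fold lower number from compound 3 to compound 4 (0.30 log units; within the scatter) even though the group on the carbonyl carbon goes from 12 heavy atoms to 5 and gains a hydrogen-bond donor. Pyrrolidin-3-yl also stays level with both other groups, with no change at the digits printed from compound 2 to compound 4 (within the scatter) against (3-carboxyphenyl)sulfonyl and no change at the digits printed from compound 1 to compound 4 (within the scatter) against 6-(dimethylamino)pyridin-3-yl, so the four compounds still cannot be ranked. Nothing measured here offers an explanation for this flat picture.

Still open, on these data alone, is whether an open-chain amine or a piperidin-4-yl ring on that carbonyl carbon would give a step beyond the scatter. The other stereocentre of the pyrrolidin-3-yl group also remains an open question.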